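The source may report more compounds than this note shows. Statements on the series, on what has been measured and on what is new or still open speak of the compounds shown alone.

In a functional assay on K562 cells (Homo sapiens) for cytotoxicity, read by MTT assay, with a stated time of 72 h (on this read-out higher numbers stand for weaker inhibition and lower numbers for stronger inhibition), compound 1 `O=C1NC(=S)S/C1=C\c1c[nH]c2ccccc12` gives > 50000 nM, a limit of the assay rather than a number. Compound 2 `NN1C(=O)/C(=C/c2c[nH]c3ccc(Br)cc23)SC1=S` also reaches only a limit in this assay, with > 50000 nM. Both values sit at the limit of > 50000 nM in this assay, at which 2 of the 2 values shown sit, so compound 2 stands nowhere distinct from compound 1. Compound 3 `O=C1NC(=S)S/C1=C\c1c[nH]c2ccc(Br)cc12` is still to be measured in this assay. It differs from compound 2 by hydrogen in place of amino on an amide-type nitrogen in a ring. Among the compounds with values here, no step between measured compounds is known here. With both neighbours at the limit, the expected step is a step that the limit leaves unreadable from compound 2 to compound 3, none beyond the scatter. Compound 3 is estimated at 60000 nM, between 20000 nM and 200000 nM.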

Compound 3, half-maximal inhibitory concentration: > 50000 nM
Compound 3: only a limit was reported; the forecaster's own chance of this, stated with the estimate: 80%; the middle value does not contradict the limit.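

Compound 3 gives > 50000 nM, a limit and not a number. No step from compound 1 or compound 2 to compound 3 can be read, because all three sit at the same limit: the limit of > 50000 nM in this assay, at which 3 of the 3 values shown sit.

From the compounds shown here alone, what the bromo and amino groups change in these compounds stays open, as does the true strength of each compound.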